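A few compounds are considered here, and "the series" means these few. Any claim that something is new, unique, unknown or untested is made for them only; others in the source may bear on it.

Compound 1 `Cc1nc(-c2cccc(F)c2)c(C(=O)N2CCN(c3cccc(Cl)c3)CC2)o1`: 33.7 nM
Compound 2 `COc1ccc(-c2nc(C)oc2C(=O)N2CCN(c3cccc(Cl)c3)CC2)cc1`: "not active" (no number reported)

In a functional assay on HL-60 cells (Homo sapiens) for inhibition, read by MTT assay, with a stated time of 72 h (on this read-out lower numbers stand for stronger inhibition and higher numbers for weaker inhibition), compound 1 gives 33.7 nM, whereas compound 2 has no number and stands only as "not active" (no number reported). Compound 3 `COc1cccc(-c2nc(C)oc2C(=O)N2CCN(c3cccc(Cl)c3)CC2)c1` has not yet been measured. The structural change is 3-methoxyphenyl in place of 4-methoxyphenyl on an aromatic carbon, with 3-methoxyphenyl in place of 4-methoxyphenyl on an aromatic carbon and the same atoms joined differently. Among the measured compounds shown here, no measured step gives a size for this change. A large step towards stronger inhibition is expected, although another result without a number remains possible. Compound 3 is estimated at 150 nM, with an expected range of 25 nM to 1500 nM.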

Compound 3, half-maximal inhibitory concentration: "not active" (no number reported)
For compound 3 the study gives words and no number; the estimate stays without a comparison.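

Compound 2 and compound 3 both stand in this assay only as "not active", so no step can be read between them. The compounds shown leave open how 3-methoxyphenyl and 4-methoxyphenyl compare in size. Nothing further shown bears on this result.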